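Methyl Added to Two Related Cores

This account rests on a few compounds, and the source may have more. Where it says the series, first, only, none or still open, it means among the compounds named here.

Compound 1 `CC(C)(C)C/N=C(/NC#N)Nc1cccnc1` and compound 2 `CC(/N=C(/NC#N)Nc1cccnc1)C(C)(C)C` share a core, and compound 3 `CC(C)(C)CN/C(=C\[N+](=O)[O-])Nc1cccnc1` and compound 4 `CC(N/C(=C\[N+](=O)[O-])Nc1cccnc1)C(C)(C)C` share another; the difference between the two cores is not broken down here. In a functional assay for inhibition, with Rattus norvegicus as the target (a lower number here means a stronger inhibitor, a higher number a weaker inhibitor), compound 1 gives 100 nM, compound 2 gives 15.9 nM, and compound 3 gives 1000 nM, the weakest of the three measured. Between compound 1 and compound 2 the change is methyl in place of hydrogen on a saturated chain carbon bound to a double-bonded nitrogen and a saturated chain carbon, and it gave a 6.3-fold lower number from compound 1 to compound 2 (0.80 log units; beyond the scatter). The change from compound 3 to compound 4 is methyl in place of hydrogen on a saturated chain carbon bound to an amine nitrogen and a saturated chain carbon; the place differs, a double-bonded nitrogen in the first pair against an amine nitrogen in the second, so this is the same kind of change rather than the same. Because of a 6.3-fold lower number from compound 1 to compound 2 (0.80 log units; beyond the scatter), compound 4 is expected to show a 5.0-fold lower number from compound 3 to compound 4 (0.70 log units; beyond the scatter) in this assay, giving an estimated 200 nM, between 60 nM and 700 nM.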

Compound 4, half-maximal inhibitory concentration: 31.6 nM
Compound 4: middle estimate off by 6.3-fold (0.80 log units), on the high side; measured number below the stated range.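

In this assay, the same methyl, turning neopentyl into 1,2,2-trimethylpropyl, gave a 32-fold lower number from compound 3 to compound 4 (1.50 log units; beyond the scatter) on the second core, so the number fell again, but by more than on the first. The direction of the change carried over from one core to the other, while its size did not: the same change on two cores in this assay, a 6.3-fold lower number (0.80 log units; beyond the scatter) from compound 1 to compound 2 and a 32-fold lower number (1.50 log units; beyond the scatter) from compound 3 to compound 4, 5.0-fold (0.70 log units) apart, beyond the scatter of two such steps. Two pairs cannot show why the size differs, and they do not predict what this methyl would do on any further core.

The compounds shown leave open whether an ethyl group or a longer chain on that same carbon would lower the number further, on either core.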